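Adding a fluorine to a pyrimidine-linked aminobenzothiazole

The compounds below may be only part of what the source reports. "The series", "measured", "known", "first", "only" and "open" are said of these compounds alone.

Compound 1, `NS(=O)(=O)c1ccc(Nc2ncc(F)c(Nc3nc4ccccc4s3)n2)cc1`: in a functional assay on PC-3 cells (Homo sapiens) for antiproliferative activity, read by MTT assay, with a stated time of 48 h (a lower number here means a stronger inhibitor, a higher number a weaker inhibitor), compound 1 gives > 50000 nM, a limit of the assay.
Compound 2, `CS(=O)(=O)c1ccc(Nc2nccc(Nc3nc4ccc(F)cc4s3)n2)cc1`: compound 2 gives 1940 nM.
Compound 3, `Cc1cnc(Nc2ccc(Cl)cc2)nc1Nc1nc2ccccc2s1`: compound 3 gives > 50000 nM, also a limit of the assay.

For the measured compounds named here, compound 2 holds the only measured number among the three; the other two values sit at the limit of > 50000 nM in this assay, at which 2 of the 3 values shown sit. Compound 4, `CS(=O)(=O)c1ccc(Nc2ncc(F)c(Nc3nc4ccc(F)cc4s3)n2)cc1`, is not yet measured. It differs from compound 2 in one place: fluoro in place of hydrogen on an aromatic carbon. Going by the values given here, no pair of measured compounds differs in this way alone, so the size of this step is unknown. Compound 1 also carries a fluoro on the same ring, and its value is a limit. Compound 1 differs from compound 2 in two further places, so it does not isolate this change. The expected step is a 1.5-fold higher number from compound 2 to compound 4 (0.19 log units; within the scatter), a mild weakening at most. Compound 4 is therefore estimated at 3000 nM, within 800 nM to 15000 nM.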

Compound 4, half-maximal inhibitory concentration: > 50000 nM
Compound 4: a limit, no number; the forecaster's own chance of this, stated with the estimate: 15%; middle value at least 16-fold (1.22 log units) away from the limit.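

In this assay, a single fluoro in place of hydrogen at this position is a large change, not the mild one the scatter might have hidden: the result is an at least 25-fold higher number from compound 2 to compound 4 (1.41 log units; beyond the scatter). Compound 4 gives > 50000 nM, which is a limit of the assay and not a number. The step therefore has a lower bound but no measured size, and this one atom is enough to move compound 2's scaffold to the value shared by most compounds here: the limit of > 50000 nM in this assay, at which 3 of the 4 values shown sit.

The compounds shown leave open how far past the limit compound 4 really lies. They also leave open whether an amine or a nitrile on this same carbon would reach the limit too.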